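Swapping a fluorophenyl amide for an oxazole amide

The compounds below may be only part of what the source reports. "The series", "measured", "known", "first", "only" and "open" are said of these compounds alone.

Three compounds share one core and differ only in the group attached to the amide carbonyl. In an assay on LtK cells with ATP-sensitive inward rectifier potassium channel 11 (Homo sapiens) as the target (a lower number here means that less compound is needed, a higher number that more compound is needed for the effect), compound 1 `CC(=O)Nc1c(C(O)(C(F)(F)F)C(F)(F)F)ccc2ccccc12` gives 18 nM, compound 2 `COCC(=O)Nc1c(C(O)(C(F)(F)F)C(F)(F)F)ccc2ccccc12` gives 213 nM, and compound 3 `O=C(Nc1c(C(O)(C(F)(F)F)C(F)(F)F)ccc2ccccc12)c1ccc(F)cc1` gives 70 nM, the second highest of the three numbers. The steps into compound 3 were a 3.9-fold higher number from compound 1 to compound 3 (0.59 log units; beyond the scatter) and a 3.0-fold lower number from compound 2 to compound 3 (0.48 log units; beyond the scatter), both modest. Compound 4 `O=C(Nc1c(C(O)(C(F)(F)F)C(F)(F)F)ccc2ccccc12)c1cnco1` carries the change (1,3-oxazol-5-yl in place of 4-fluorophenyl on a carbonyl carbon). Among the compounds with values here, no measured step swaps one aromatic ring for another, so only a modest move is expected, with compound 3 and compound 4 likely close to each other: the estimated step is a 1.4-fold higher number from compound 3 to compound 4 (0.15 log units; within the scatter). Compound 4 is therefore expected to give about 100 nM, with a range from 30 nM to 300 nM in this assay.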

Compound 4, half-maximal effective concentration: 24 nM
Beside the measured number, compound 4's estimate is 4.2-fold (0.62 log units) above it; the whole stated range lies above it.
By their numbers in this assay, from the lowest: compounds 1 and 4 (each within the scatter of the next); then compound 3; then compound 2.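

Which aromatic ring sits on the carbonyl carbon matters: 1,3-oxazol-5-yl in place of 4-fluorophenyl gives a 2.9-fold lower number from compound 3 to compound 4 (0.46 log units; beyond the scatter), a difference the earlier compounds could not show. An aromatic ring here need not give a higher number than methyl, as a 1.3-fold higher number from compound 1 to compound 4 (0.12 log units; within the scatter) shows, although compound 3 goes against this. Methoxymethyl compares poorly with the new ring, with an 8.9-fold lower number from compound 2 to compound 4 (0.95 log units; beyond the scatter), and no measurement shown explains these differences.

From the compounds shown here alone, how a plain phenyl or a pyridine ring would compare remains open. So does whether the fluorine or the ring type counts more.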